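This account rests on a few compounds, and the source may have more. Where it says the series, first, only, none or still open, it means among the compounds named here.

Compound 1 (`COc1ccc(Nc2cc(Oc3c(C)cc(Br)cc3C)c([N+](=O)[O-])cc2[N+](=O)[O-])cc1`) – 51200 nM
Compound 2 (`Cc1cc(C)c(Oc2ccc(N)c(Nc3ccc(C#N)cc3)c2)c(C)c1`) – 51000 nM

Both compounds were tested in an ADME assay on H9 cells (Homo sapiens) for cytotoxicity, read by XTT assay, with a stated time of 6 days; on this read-out lower numbers stand for higher toxicity in this test and higher numbers for lower toxicity in this test. Compound 1 gives 51200 nM and compound 2 gives 51000 nM, so the two stand level within the usual scatter, and compound 1 has no measured neighbour clearly separated from it.

The next compound is compound 3 (`COc1ccc(Nc2cc(Oc3c(C)cccc3C)c([N+](=O)[O-])cc2[N+](=O)[O-])cc1`), which keeps the core of compound 1 and differs from it in one place: hydrogen in place of bromo on an aromatic carbon. Hydrogen stands in place of bromo on an aromatic carbon, turning the 4-bromo-2,6-dimethylphenyl group into 2,6-dimethylphenyl. Going by the values given here, no measured pair of compounds shows what this exchange does, so the expectation rests only on compound 1 at 51200 nM and on the modest size of the change. No step beyond the scatter is expected in this assay, and no direction can be favoured. The estimate amounts to an expected 1.0-fold lower number from compound 1 to compound 3 (0.01 log units; within the scatter). For compound 3 the estimated value is 50000 nM, with an expected range from 15000 nM to 120000 nM.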

Compound 3, half-maximal cytotoxic concentration: > 61100 nM
Compound 3: no number, only a limit; the forecaster's own chance of this, stated with the estimate: 20%; at least 1.2-fold (0.08 log units) between middle value and limit.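

In this assay compound 3 gives > 61100 nM, which is a limit of the assay and not a number. Hydrogen in place of bromo on this aromatic carbon, meta to two methyl groups and para to a large group, gives an at least 1.1-fold higher number from compound 1 to compound 3 (0.07 log units; that floor lies within the scatter), so this first look at the position shows no sign that losing the bromo group brings the number down in this test. The true size of the step stays unread, and the reading is bounded by the top of the measured range: the limit of > 61100 nM in this assay, at which 1 of the 3 values shown sits.

The compounds shown leave open how far past its limit compound 3 really lies, and therefore whether the exchange has any effect beyond the scatter or none at all. They also leave open whether a chloro group, a methoxy group or an amine at the same position would behave like bromo or like hydrogen, and whether the same exchange would read alike on a core other than that of compound 1.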